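Urea aryl swap on a shared pyrazolopyrimidine-piperidine scaffold

The compounds below may be only part of what the source reports. "The series", "measured", "known", "first", "only" and "open" are said of these compounds alone.

Measured compounds:
compound 1 `O=C(NC1CCN(c2ncnc3[nH]ncc23)CC1)c1cccc(Cl)c1Cl`: 4170 nM
compound 2 `O=C(Nc1ccc(Br)cc1)NC1CCN(c2ncnc3[nH]ncc23)CC1`: 4030 nM

In an assay on isolated protein for inhibition of serine/threonine-protein kinase PAK 1 (Homo sapiens), read by ADP-Glo, with a stated time of 40 min (a higher number here means a weaker inhibitor, a lower number a stronger inhibitor), compound 1 gives 4170 nM, and compound 2 gives 4030 nM. Going by the values given here, compound 2 stands as the lowest of the two numbers, but the only measured step, a 1.0-fold lower number from compound 1 to compound 2 (0.01 log units; within the scatter), lies within the scatter, so the two compounds are not separated by this assay.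

Compound 3 `O=C(Nc1ccccc1Cl)NC1CCN(c2ncnc3[nH]ncc23)CC1` is not yet measured. It differs from compound 2 by 2-chlorophenyl in place of 4-bromophenyl on an amide-type nitrogen. Among the compounds with values here, no measured step changes only the halogen or its place on the phenyl ring; the single step at hand, from compound 1 to compound 2, altered the aryl group together with the linkage and produced no shift beyond the scatter. On that basis no step beyond the scatter is expected, a 1.1-fold higher number from compound 2 to compound 3 (0.05 log units; within the scatter). Compound 3 is therefore estimated at 4500 nM, with a range from 1500 nM to 13000 nM.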

Compound 3, half-maximal inhibitory concentration: 560 nM
Compound 3: middle estimate off by 8.0-fold (0.91 log units), on the high side, outside the stated range (below it).
By their numbers in this assay, from the lowest: compound 3; then compounds 2 and 1 (each within the scatter of the next).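

In this assay, the aryl group on this amide-type nitrogen proves able to move the number: 2-chlorophenyl in place of 4-bromophenyl gives a 7.2-fold lower number from compound 2 to compound 3 (0.86 log units; beyond the scatter), though both groups have the same count of heavy atoms and the same kind of ring. The earlier step within the scatter therefore does not hold as a general reading of this part of the molecule, since a further change at this same part gives a 7.4-fold lower number from compound 1 to compound 3 (0.87 log units; beyond the scatter). No measurement at hand gives a reason for either step.

The step from 4-bromophenyl to 2-chlorophenyl changes both the halogen and its place on the ring, so the compounds shown cannot say which of the two matters. Going by these compounds, that question stays open, as does what 2-bromophenyl, 4-chlorophenyl or 2-methoxyphenyl would give on the same nitrogen.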